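Replacing trifluoromethyl with fluoro on an aromatic carbon

The compounds below may be only part of what the source reports. "The series", "measured", "known", "first", "only" and "open" are said of these compounds alone.

Compound 1 `CCCNC(=O)c1cc(Oc2ccc(NC(=O)c3nn(-c4ccc(Br)cc4F)c(=O)cc3C)cc2F)ccn1`: "not active" (no number reported)
Compound 2 `CCCNC(=O)c1cc(Oc2ccc(NC(=O)c3nn(-c4cccc(C(F)(F)F)c4)c(=O)cc3C)cc2F)ccn1`: 30000 nM

Among the measured compounds shown here, in a functional assay on MCF7 cells (Homo sapiens) for antiproliferative activity, read by MTT assay, with a stated time of 72 h (a higher number here means a weaker inhibitor, a lower number a stronger inhibitor), compound 2, at 30000 nM, holds the only number available, since compound 1 was reported as "not active" (no number reported) without one. Compound 3 `CCCNC(=O)c1cc(Oc2ccc(NC(=O)c3nn(-c4cccc(F)c4)c(=O)cc3C)cc2F)ccn1` has not yet been measured. It carries fluoro in place of trifluoromethyl on an aromatic carbon, meta to a large group: fluoro in place of trifluoromethyl on an aromatic carbon. For the measured compounds named here, no measured pair shows what such a change does, so the expectation rests on compound 2 at 30000 nM. The expected step, a 1.5-fold lower number from compound 2 to compound 3 (0.18 log units; within the scatter), is none beyond the scatter in this assay. For compound 3 the estimated value is 20000 nM, with an expected range from 7000 nM to 60000 nM.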

Compound 3, half-maximal inhibitory concentration: 13300 nM
For compound 3 the middle estimate is 1.5-fold (0.18 log units) above the measured one; low and high end bracket the measured number.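

In this assay, this position responds to the exchange of trifluoromethyl for fluoro, with a 2.3-fold lower number from compound 2 to compound 3 (0.35 log units; beyond the scatter). Among the compounds shown here, this is the first measured step at this position, and it favours 3-fluorophenyl over 3-(trifluoromethyl)phenyl, though only modestly. Nothing measured here explains the step. As far as these compounds go, it remains open whether an amine, a methoxy group or a carboxylic acid at this position would shift the number further. From the compounds shown here alone, whether the step would hold with the same exchange elsewhere on this aromatic ring also remains open.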